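This account rests on a few compounds, and the source may have more. Where it says the series, first, only, none or still open, it means among the compounds named here.

Among the measured compounds shown here, compound 2 `O=[N+]([O-])c1cc(-c2nnn(Cc3ccc(F)cc3)n2)cc([N+](=O)[O-])c1` stands lowest of the two numbers so far in an ADME assay on CHO-K1 cells (Cricetulus griseus) for cytotoxicity, read by MTT assay, with a stated time of 24 h (on this read-out higher numbers stand for weaker inhibition and lower numbers for stronger inhibition), where compound 2 gives 35000 nM. For the measured compounds named here, compound 1 `Cc1ccc(Cn2nnc(-c3cc([N+](=O)[O-])cc([N+](=O)[O-])c3)n2)cc1` gives 200000 nM, and the single step so far, a 5.7-fold lower number from compound 1 to compound 2 (0.76 log units; beyond the scatter), was modest. Compound 3 `O=[N+]([O-])c1cc(-c2nnn(Cc3ccc(Cl)c(Cl)c3)n2)cc([N+](=O)[O-])c1` differs from compound 2 by 3,4-dichlorophenyl in place of 4-fluorophenyl on a saturated chain carbon bound to an aromatic nitrogen. Going by the values given here, no measured step covers this change directly; the one step available concerns a different swap at the same place, so the expectation rests loosely on it. A modest lowering is therefore expected, a 1.8-fold lower number from compound 2 to compound 3 (0.24 log units; within the scatter), with compound 3 estimated at 20000 nM, range 7000 nM to 70000 nM.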

Compound 3, half-maximal inhibitory concentration: 37000 nM
Compound 3: middle estimate off by 1.9-fold (0.27 log units), on the low side; measured number inside the range.
By their numbers in this assay, from the lowest: compounds 2 and 3 (each within the scatter of the next); then compound 1.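

In this assay, the swap at this place, on a saturated chain carbon bound to an aromatic nitrogen, leaves the number within the scatter, with a 1.1-fold higher number from compound 2 to compound 3 (0.02 log units; within the scatter) between the two halogen-bearing rings. Set against 4-methylphenyl, 3,4-dichlorophenyl gives a 5.4-fold lower number from compound 1 to compound 3 (0.73 log units; beyond the scatter), so among these three compounds only compound 1 stands apart. Nothing measured here accounts for this.

As far as these compounds go, whether that separation holds beyond these three rings stays open. Also open, from the compounds shown here alone, is what an amine or a carboxylic acid on this ring, or a longer chain in this place, would give.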